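A few compounds are considered here, and "the series" means these few. Any claim that something is new, unique, unknown or untested is made for them only; others in the source may bear on it.

Compound 1 `COc1cc(Oc2ccccc2NC(C)=C2C(=O)CC(c3ccccc3)CC2=O)ccc1N` — 12 nM
Compound 2 `CC(Nc1ccccc1Oc1cccc(F)c1)=C1C(=O)CC(c2ccccc2)CC1=O` — 170 nM
Compound 3 `CC(Nc1ccccc1Oc1cccc(N)c1)=C1C(=O)CC(c2ccccc2)CC1=O` — 42 nM

Three compounds sharing one core were tested in a functional assay on CCRF-CEM cells (Homo sapiens) for antiproliferative activity, read by cell counting, with a stated time of 96 h; a lower number here means a stronger inhibitor, a higher number a weaker inhibitor. Compound 3 sits second highest of the three numbers: compound 1 lies beneath it, and the step of a 3.5-fold higher number from compound 1 to compound 3 (0.54 log units; beyond the scatter) is beyond the scatter, while compound 2 lies above it, and the step of a 4.0-fold lower number from compound 2 to compound 3 (0.61 log units; beyond the scatter) is likewise beyond the scatter. The gap across the whole set is a 14-fold higher number from compound 1 to compound 2 (1.15 log units; beyond the scatter).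

Compound 4 `CC(Nc1ccccc1Oc1ccc(C(C)O)cc1)=C1C(=O)CC(c2ccccc2)CC1=O` has not yet been measured in this assay. It differs from compound 3 in one place: 4-(1-hydroxyethyl)phenyl in place of 3-aminophenyl on an oxygen on an aromatic ring. For the measured compounds named here, no measured pair shows a hydroxyethyl group entering or an amino group leaving this phenyl ring, so the measured steps bear on it only loosely. The step of a 4.0-fold lower number from compound 2 to compound 3 (0.61 log units; beyond the scatter) shows that the amino group on this ring mattered by a modest amount, and its removal in compound 4 may therefore cost something, though the entering group carries its own donor and acceptor. A modest rise in the number is expected for compound 4, a 1.7-fold higher number from compound 3 to compound 4 (0.22 log units; within the scatter), with wide uncertainty, giving an estimate of 70 nM in a range of 25 nM to 200 nM.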

Compound 4, half-maximal inhibitory concentration: 120 nM
Estimate against measurement, compound 4: 1.7-fold (0.23 log units) below; measured number inside the range.
By their numbers in this assay, from the lowest: compound 1; then compound 3; then compounds 4 and 2 (each within the scatter of the next).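

In this assay, the 4-(1-hydroxyethyl)phenyl group on this oxygen does not keep what the 3-aminophenyl group gave, with a 2.9-fold higher number from compound 3 to compound 4 (0.46 log units; beyond the scatter), even though the two groups count the same hydrogen-bond donors and acceptors. The same group gives a 1.4-fold lower number from compound 2 to compound 4 (0.15 log units; within the scatter), which leaves that pair within the scatter, and a 10-fold higher number from compound 1 to compound 4 (1.00 log units; beyond the scatter), so among these four compounds the two carrying an amino group on this ring give the lowest numbers, with no compound going against this. Nothing at hand accounts for this difference.

Compound 4 loses the amino group and gains the hydroxyethyl group in one change, so the compounds shown leave open how much of the step belongs to each. A hydroxymethyl group, a carboxylic acid, or an amine carried on the same ring as the hydroxyethyl group would bear on that question.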